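Sugar ring exchange on a nitrobenzyl purine nucleoside

The compounds below may be only part of what the source reports. "The series", "measured", "known", "first", "only" and "open" are said of these compounds alone.

Two nucleosides share the nitrobenzylamino purine core and differ only in the sugar attached to the ring nitrogen. Compound 1 `O=[N+]([O-])c1ccc(CNc2ncnc3c2ncn3[C@H]2C[C@H](O)[C@@H](CO)O2)cc1` gives in an assay on isolated protein for binding affinity to Equilibrative nucleoside transporter 1 (Homo sapiens) (on this read-out higher numbers stand for weaker inhibition and lower numbers for stronger inhibition), a value of 15.9 nM. Compound 2 `O=[N+]([O-])c1ccc(CNc2ncnc3c2ncn3[C@@H]2O[C@H](CO)C[C@H]2O)cc1` gives in this assay a value of 977 nM, the highest of the two numbers, and the step of a 61-fold higher number from compound 1 to compound 2 (1.79 log units; beyond the scatter) shows how strongly the sugar part moves this read-out.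

Compound 3 `O=[N+]([O-])c1ccc(CNc2ncnc3c2ncn3[C@@H]2O[C@H](CCl)[C@@H](O)[C@H]2O)cc1` is the next member: a group of 9 heavy atoms (5 carbon, 3 oxygen, 1 chlorine; one five-membered non-aromatic ring with 1 hetero atom) in place of a group of 8 heavy atoms (5 carbon, 3 oxygen; one five-membered non-aromatic ring with 1 hetero atom), on an aromatic nitrogen. Within the data shown here, the only measured step, from compound 1 to compound 2, does not compare this same pair of sugars, so it bears on the new change only indirectly, by showing that a single change in the oxolane ring can shift the number by far more than the scatter. A large shift is therefore expected here as well, in the direction of a lower number, since the entering group carries both ring hydroxyls that the group on compound 2 lacks in part. Compound 3 is estimated at 12 nM, within 2 nM to 80 nM, an expected step of an 81-fold lower number from compound 2 to compound 3 (1.91 log units; beyond the scatter).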

Compound 3, half-maximal inhibitory concentration: 107 nM
Compound 3: middle estimate off by 8.9-fold (0.95 log units), on the low side; the whole stated range lies below it.
By their numbers in this assay, from the lowest: compound 1; then compound 3; then compound 2.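

On the aromatic nitrogen of the shared core, the chlorine-bearing sugar gives a 9.1-fold lower number from compound 2 to compound 3 (0.96 log units; beyond the scatter) in this assay and yet also a 6.7-fold higher number from compound 1 to compound 3 (0.83 log units; beyond the scatter) on the same read-out, so this position supports an intermediate number and not only the two extremes seen before. The step from compound 2 to compound 3 arises although the leaving and entering groups have the same counts of hydrogen-bond donors and acceptors and the same five-membered ring with one hetero atom; what does change is the added chlorine and the added defined stereocentre. No available evidence speaks to why the number moves in this way.

The compounds shown leave open how much of either step belongs to the chlorine itself and how much to the other differences between these sugars, since the groups compared differ in more than one feature. They also leave open how this read-out would respond if a fluorine, an amine or a longer chain stood where the chlorine stands in compound 3.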